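A few compounds are considered here, and "the series" means these few. Any claim that something is new, unique, unknown or untested is made for them only; others in the source may bear on it.

Measured compounds in a functional assay on MCF7 cells (Homo sapiens) for inhibition, read by MTT assay, with a stated time of 24 h; a higher number here means a weaker inhibitor, a lower number a stronger inhibitor:
compound 1 `CCOC(=O)C1=Cc2ccccc2OC1(OCc1cc(-c2ccc3ccccc3c2)no1)C(F)(F)F` – 65400 nM
compound 2 `CCOC(=O)C1=Cc2ccccc2OC1(OCc1cn(CC(=O)Nc2ccc(OC)cc2)nn1)C(F)(F)F` – 28100 nM

Of the two, compound 2 gives the lower number in this assay, and the gap to compound 1 lies beyond the usual scatter. Compound 3 `CCOC(=O)C1=Cc2ccccc2OC1(OCc1cn(-c2ccc([N+](=O)[O-])cc2)nn1)C(F)(F)F` has not been measured. It differs from compound 2 by 4-nitrophenyl in place of ((4-methoxyphenyl)carbamoyl)methyl on an aromatic nitrogen. Among the compounds with values here, no step between measured compounds shows this kind of change, so nothing in the data points in either direction. The expected step is a 1.1-fold higher number from compound 2 to compound 3 (0.03 log units; within the scatter), which means none beyond the scatter. For compound 3 the estimate in this assay is 30000 nM, within a range of 8000 nM to 120000 nM.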

Compound 3, half-maximal inhibitory concentration: > 150000 nM
Compound 3 gave a limit, no number (the forecaster's own chance of this, stated with the estimate: 15%); middle value at least 5.0-fold (0.69 log units) from the limit.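

At the aromatic nitrogen of the five-membered ring, the group matters in this assay: 4-nitrophenyl in place of ((4-methoxyphenyl)carbamoyl)methyl gives an at least 5.3-fold higher number from compound 2 to compound 3 (0.72 log units; beyond the scatter). So this position does not tolerate every group equally, which the earlier compounds could not show. The value of compound 3 is a limit, not a number: the limit of > 150000 nM in this assay, at which 1 of the 3 values shown sits.

The change swaps the carbamoyl chain and the ring substituent together, so the compounds shown do not separate the two. From the compounds shown here alone, how a plain phenyl, a 4-aminophenyl or a benzyl group would read at this nitrogen remains open.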